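Quinoline chalcones: swapping the ketone aryl group

A few compounds are considered here, and "the series" means these few. Any claim that something is new, unique, unknown or untested is made for them only; others in the source may bear on it.

The measured compounds, with their values in a functional assay on H184B5F5/M10 cells (Homo sapiens) for antiproliferative activity, read by XTT assay, with a stated time of 72 h; on this read-out lower numbers stand for stronger inhibition and higher numbers for weaker inhibition:
- compound 1, `COc1ccc(-c2cc3ccccc3nc2/C=C/C(=O)c2ccc(OC)cc2OC)cc1`, 6110 nM
- compound 2, `COc1ccc(-c2cc3ccccc3nc2/C=C/C(=O)c2ccc(OC)c(OC)c2)cc1`, 7240 nM
- compound 3, `COc1ccc(-c2cc3ccccc3nc2/C=C/C(=O)c2ccccn2)cc1`, 4140 nM

Compound 3 gives the lowest of the three numbers, but its steps to the other two are small: a 1.5-fold lower number from compound 1 to compound 3 (0.17 log units; within the scatter) and a 1.7-fold lower number from compound 2 to compound 3 (0.24 log units; within the scatter), both within the scatter, as is a 1.2-fold higher number from compound 1 to compound 2 (0.07 log units; within the scatter). The group on the carbonyl carbon has thus been changed twice without any step beyond the scatter.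

Compound 4, `COc1ccc(-c2cc3ccccc3nc2/C=C/C(=O)c2c[nH]c3ccccc23)cc1`, differs from compound 3 by 1H-indol-3-yl in place of pyridin-2-yl on a carbonyl carbon. All three measured steps bear on it, since each exchanges the group on the carbonyl carbon, and none moved the number beyond the scatter. Compound 4 is therefore expected to land close to compound 3, with a 1.2-fold lower number from compound 3 to compound 4 (0.07 log units; within the scatter), a step of no clear direction. The value of compound 4 in this assay is estimated at 3500 nM, in the range 1000 nM to 12000 nM.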

Compound 4, half-maximal inhibitory concentration: > 10000 nM
Compound 4 was reported as a limit; the forecaster's own chance of this, stated with the estimate: 5%; middle value at least 2.8-fold (0.45 log units) away from the limit.
By their numbers in this assay, from the lowest: compounds 3, 1 and 2 (each within the scatter of the next). At a limit, above all of these: compound 4.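

Compound 4 is reported in this assay only as a limit (> 10000 nM). The group on the carbonyl carbon had given no step beyond the scatter until 1H-indol-3-yl took the place of pyridin-2-yl, which gives an at least 2.4-fold higher number from compound 3 to compound 4 (0.38 log units; beyond the scatter) and shows that this position does not tolerate every exchange equally. Read as floors, an at least 1.3-fold higher number from compound 2 to compound 4 (0.14 log units; that floor lies within the scatter) and an at least 1.6-fold higher number from compound 1 to compound 4 (0.21 log units; that floor lies within the scatter) do not establish a firm order against the two dimethoxyphenyl groups, and the full size of all three steps cannot be given: the limit of > 10000 nM in this assay, at which 1 of the 4 values shown sits.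

The compounds shown do not separate the added ring of 1H-indol-3-yl from its hydrogen-bond donor. A 1-methylindol-3-yl or a benzofuran-3-yl group on the carbonyl carbon would bear on that question.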